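Diethylamino in Place of Amino: Expected Antiproliferative Potency

The source may hold more compounds than are shown below. What is called first, only, known or untested is meant among the compounds shown, and "the series" means these compounds.

Measured compounds:
compound 1 `CCCCCCCCCCCCOc1ccc(C(=O)/C=C/c2c(/C=C/c3ccc(OC)cc3)cc(OC)cc2OC)cc1` gives 12.7 ug/mL
compound 2 `COc1ccc(/C=C/c2cc(OC)cc(OC)c2/C=C/C(=O)c2ccc(Cl)c(Cl)c2)cc1` gives 7.5 ug/mL
compound 3 `COc1ccc(/C=C/c2cc(OC)cc(OC)c2/C=C/C(=O)c2ccc(N)cc2)cc1` gives 2.8 ug/mL

Among these three, compound 3 shows the lowest number in a functional assay on B16-F10 cells (Mus musculus) for antiproliferative activity, read by MTT assay, with a stated time of 48 h (on this read-out higher numbers stand for weaker inhibition and lower numbers for stronger inhibition), with compound 2 next and compound 1 furthest away. Compound 4 `CCN(CC)c1ccc(C(=O)/C=C/c2c(/C=C/c3ccc(OC)cc3)cc(OC)cc2OC)cc1` differs from compound 3 in one place: diethylamino in place of amino on an aromatic carbon. Going by the values given here, only one measured step touches this position, a 2.7-fold lower number from compound 2 to compound 3 (0.43 log units; beyond the scatter), and it exchanges a different group, so no measured step replaces amino by diethylamino. The account therefore expects no large move: the step from compound 3 to compound 4 is estimated as a 1.3-fold higher number from compound 3 to compound 4 (0.10 log units; within the scatter), within or near the scatter. Compound 4 is accordingly expected to give about 3.5 ug/mL, with a range from 1.5 ug/mL to 9 ug/mL.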

Compound 4, half-maximal inhibitory concentration: 8.1 ug/mL
The estimate for compound 4 lay 2.3-fold (0.36 log units) below the measured number, within the range that was stated.
By their numbers in this assay, from the lowest: compound 3; then compounds 2, 4 and 1 (each within the scatter of the next).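

In this assay, going by these compounds alone, this position responds to what the nitrogen carries: diethylamino in place of amino gives a 2.9-fold higher number from compound 3 to compound 4 (0.46 log units; beyond the scatter), the first measured change of the amino group itself. With a 1.1-fold higher number from compound 2 to compound 4 (0.03 log units; within the scatter), the 4-(diethylamino)phenyl and 3,4-dichlorophenyl compounds do not separate, so the advantage of 4-aminophenyl over 3,4-dichlorophenyl is not kept with diethylamino. Nothing available explains this shift. The compounds shown leave open whether ethylamino, dimethylamino or a pyrrolidine ring at this place would read like compound 3 or like compound 4.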